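The source may report more compounds than this note shows. Statements on the series, on what has been measured and on what is new or still open speak of the compounds shown alone.

Measured compounds, inhibition constants in the assay described below:
compound 1 `CCC1CCN(c2nc(C(C)(C)C)ccc2CNC(=O)C(C)c2ccc(NS(C)(=O)=O)c(F)c2)CC1` — 0.1 nM
compound 2 `CC(C(=O)NCc1ccc(C(C)(C)C)nc1OC1CCCC1)c1ccc(NS(C)(=O)=O)c(F)c1` — 1.5 nM
compound 3 `CCCCCSc1nc(C(C)(C)C)ccc1CNC(=O)C(C)c1ccc(NS(C)(=O)=O)c(F)c1` — 3.1 nM

In an assay on cells for antagonist activity at transient receptor potential cation channel subfamily V member 1 (Homo sapiens), read by FLIPR and calcium flux, with a stated time of 6 min (a higher number here means a weaker inhibitor, a lower number a stronger inhibitor), compound 3 carries the highest number of the three: the step of a 31-fold higher number from compound 1 to compound 3 (1.49 log units; beyond the scatter) is large, the step of a 2.1-fold higher number from compound 2 to compound 3 (0.32 log units; beyond the scatter) modest, and the step of a 15-fold higher number from compound 1 to compound 2 (1.18 log units; beyond the scatter) large. All three measured steps swap the whole substituent on the aromatic carbon of the shared core.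

Compound 4 `CCCCCCSc1nc(C(C)(C)C)ccc1CNC(=O)C(C)c1ccc(NS(C)(=O)=O)c(F)c1` extends that substituent: methyl in place of hydrogen on a saturated chain carbon, five bonds along the chain from a sulfur. Going by the values given here, no measured pair shows a chain lengthened by one carbon, so there is no direct precedent. The measured steps compare unlike groups, not homologues, and give no indication that one further chain carbon should shift the number beyond the scatter in either direction. The working expectation is therefore a step of about none, and the estimate for the step is a 1.0-fold lower number from compound 3 to compound 4 (0.01 log units; within the scatter).

Compound 4 is expected to give in this assay about 3 nM, with a range of 1.2 nM to 8 nM.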

Compound 4, inhibition constant: 1.5 nM
Beside the measured number, compound 4's estimate is 2.0-fold (0.30 log units) above it; the range from low to high includes it.
By their numbers in this assay, from the lowest: compound 1; then compounds 2 and 4 (each within the scatter of the next); then compound 3.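

In this assay, going by these compounds alone, this is the first pair that lengthens a chain by one carbon, and methyl in place of hydrogen on a saturated chain carbon, five bonds along the chain from a sulfur, gives a measurable gain (a 2.1-fold lower number from compound 3 to compound 4 (0.32 log units; beyond the scatter)), so the far end of the sulfur-linked chain still affects the number, if only modestly. Hexylsulfanyl and cyclopentyloxy cannot be told apart on the aromatic carbon (no change at the digits printed from compound 2 to compound 4 (within the scatter)), whereas 4-ethylpiperidin-1-yl keeps a large lead over hexylsulfanyl (a 15-fold higher number from compound 1 to compound 4 (1.18 log units; beyond the scatter)), so the added carbon closes the gap to cyclopentyloxy but not to the piperidine. No measurement is available that explains the effect of the added carbon.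

As far as these compounds go, a single homologue pair gives no trend, so it remains open whether heptylsulfanyl or a longer chain would lower the number further or reverse the step. Also open, from the compounds shown here alone, is whether hexyloxy would match hexylsulfanyl, and whether an open-chain amine such as hexylamino would approach the 4-ethylpiperidin-1-yl compound.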